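The source may report more compounds than this note shows. Statements on the series, on what has been measured and on what is new or still open speak of the compounds shown alone.

Of the compounds shown here, three have been measured in a functional assay on microsomes for inhibition, with a stated time of 1 h; on this read-out lower numbers stand for stronger inhibition and higher numbers for weaker inhibition. Compound 3 `Cn1c(NN)nc(-c2ccccc2O)c(C#N)c1=O` gives 34 ug/mL, and compound 1 `CSc1nc(-c2ccccc2O)c(C#N)c(=O)n1C` gives 44 ug/mL. The two differ in one place: methylsulfanyl in place of aminoamino on an aromatic carbon. This change produced a 1.3-fold higher number from compound 3 to compound 1 (0.11 log units; within the scatter). Compound 2 `COc1cccc(-c2nc(NN)n(C)c(=O)c2C#N)c1OC` gives 37 ug/mL in this assay; how its core differs from that of compound 3 is not broken down here, and the values of compound 2 and compound 3 sit close together.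

Compound 4 `COc1cccc(-c2nc(SC)n(C)c(=O)c2C#N)c1OC` has not yet been measured. It differs from compound 2 in one place: methylsulfanyl in place of aminoamino on an aromatic carbon. The surroundings of the place match those of the earlier pair except that here the place is meta to a large group, where for compound 3 and compound 1 it was meta to a group of 7 heavy atoms, so the two changes are of the same kind rather than the same. Because the earlier change gave a 1.3-fold higher number from compound 3 to compound 1 (0.11 log units; within the scatter), the expected step is a 1.2-fold higher number from compound 2 to compound 4 (0.09 log units; within the scatter), set beside that earlier one. On this basis compound 4 is estimated at 45 ug/mL in this assay, with a likely range from 25 ug/mL to 80 ug/mL.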

Compound 4, half-maximal inhibitory concentration: 48 ug/mL
The estimate for compound 4 lay 1.1-fold (0.03 log units) below the measured number, and the stated range covers the measured number.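

In this assay, methylsulfanyl in place of aminoamino on the core of compound 2 gave a 1.3-fold higher number from compound 2 to compound 4 (0.11 log units; within the scatter), so the swap that had barely registered on the core of compound 1 barely registered here either. Set side by side, the two steps agree: the same change on two cores in this assay, a 1.3-fold higher number (0.11 log units; within the scatter) from compound 3 to compound 1 and a 1.3-fold higher number (0.11 log units; within the scatter) from compound 2 to compound 4, 1.0-fold (0.00 log units) apart, within the scatter of two such steps What this supports is a modest claim: across these two cores, the exchange of aminoamino for methylsulfanyl at this place left the number within the usual scatter, but since neither step stands clear of that scatter, it does not establish a real effect of the change in either case, and two cores cannot show that the same would hold on a third.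

The compounds shown leave open whether any other group at this place, such as a simple amine, a longer chain like ethylsulfanyl or a carboxylic acid, would move the number beyond the scatter. They also leave open whether this exchange would behave the same way in any other read-out.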